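The compounds below may be only part of what the source reports. "The series", "measured", "known", "first", "only" and "open" are said of these compounds alone.

Compound 1 `CC(=O)C1=C(C)NC(=O)NC1c1ccoc1` gives 6% in an assay on membranes from CHO cells for displacement of a labelled ligand from adenosine receptor A1 (Homo sapiens), read by scintillation counting, with a stated time of 60 min, tested at 1 uM (a higher number here means more inhibition at the concentration tested (going by the name of the read-out), a lower number less inhibition), the lowest of the three numbers at hand. Compound 2 `CC(=O)C1=C(C)NC(=O)NC1c1ccsc1` gives 9%; the change a number 3 percentage points higher from compound 1 to compound 2 (within the scatter) lies within the scatter. Compound 3 `CC1=C(c2ncc(C)o2)C(c2ccoc2)NC(=O)N1` gives 21%, a step of a number 15 percentage points higher from compound 1 to compound 3 (beyond the scatter) that is beyond the scatter. Compound 4 `CC1=C(C(=O)OC2CCC2)C(c2ccoc2)NC(=O)N1` keeps the core of compound 1 and differs by cyclobutyloxy in place of methyl on a carbonyl carbon. For the measured compounds named here, only the step from compound 1 to compound 3 touches the acetyl group, and it replaced the whole group rather than the methyl alone, so it bears on the present change only loosely. The step from compound 1 to compound 2 does not bear on it. A small rise, if any, is expected, the estimated step being a number 6 percentage points higher from compound 1 to compound 4 (within the scatter). Compound 4 is therefore estimated at 12%, within 0% to 30%.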

Compound 4, a percentage reported as inhibition, at one concentration (the size of the read-out at that concentration, not a potency): 20%
The estimate for compound 4 lay 8 percentage points below the measured number; the measured number falls inside the stated range.
By their numbers in this assay, from the lowest: compounds 1 and 2 (each within the scatter of the next); then compounds 4 and 3 (each within the scatter of the next).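

On the carbonyl carbon, cyclobutyloxy in place of methyl gives a number 14 percentage points higher from compound 1 to compound 4 (beyond the scatter) in this assay, showing that this position responds to a change that keeps the carbonyl, which the earlier replacement of the whole acetyl group could not show. Compound 4 gives 20% and compound 3 gives 21%, within the scatter of each other. No measurement at hand accounts for the step.

Going by these compounds, whether the rise needs the four-membered ring or the added oxygen stays open. Methoxy, an open butyloxy chain or an amine on the same carbonyl carbon would separate these.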